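From compound 2 to compound 4: methyl in place of hydrogen

The source may report more compounds than this note shows. Statements on the series, on what has been measured and on what is new or still open speak of the compounds shown alone.

Three compounds carry results in a functional assay on MGC-803 cells (Homo sapiens) for inhibition, read by MTT assay, with a stated time of 48 h; a higher number here means a weaker inhibitor, a lower number a stronger inhibitor. Compound 1 `COc1ccc(CNc2cc(OC)c(OC)c(OC)c2)cc1Br` gives 29400 nM, and compound 3 `C/C=C/C(=O)N(Cc1ccc(OC)c(OC)c1)c1cc(OC)c(OC)c(OC)c1` gives 20100 nM. Compound 2 `COc1cc(NCc2ccccc2)cc(OC)c1OC` returns only a limit, > 80000 nM, which is not a number, and it sits at the limit of > 80000 nM in this assay, at which 1 of the 3 values shown sits. Compound 2 therefore stands at the weak edge of what has been measured so far, with no numerical value of its own to build on.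

Compound 4 `COc1cc(NCc2ccc(C)cc2)cc(OC)c1OC` is the next compound, not yet measured in this assay. It differs from compound 2 by methyl in place of hydrogen on an aromatic carbon; the same difference, cut one bond further out, reads phenyl to 4-methylphenyl. Among the compounds with values here, no pair of measured compounds differs in one place only, so no measured step shows what a change of this kind does here. A single methyl is a small alteration in size, and the step expected is an at least 1.3-fold lower number from compound 2 to compound 4 (0.12 log units; that floor lies within the scatter), pointing, if anywhere, toward a somewhat stronger inhibitor but not clearly beyond the usual scatter. Compound 4 is estimated at 60000 nM, within 25000 nM to 120000 nM, and a limit rather than a number remains a real possibility.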

Compound 4, half-maximal inhibitory concentration: > 80000 nM
Compound 4: no number, only a limit (the forecaster's own chance of this, stated with the estimate: 45%); at least 1.3-fold (0.12 log units) between middle value and limit.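

Compound 2 and compound 4 both return a limit rather than a number, so no step between them can be read for methyl in place of hydrogen, because both sit at the same limit: the limit of > 80000 nM in this assay, at which 2 of the 4 values shown sit.

The compounds shown leave open whether this methyl shifts inhibition in either direction, and by how much.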